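The compounds below may be only part of what the source reports. "The series", "measured", "known", "first", "only" and "open" are said of these compounds alone.

Of the compounds shown here, three share one core and have been tested in an ADME assay on HepG2 cells (Homo sapiens) for cytotoxicity, read by MTT assay, with a stated time of 7 days; a lower number here means a stronger inhibitor, a higher number a weaker inhibitor. Compound 1 `O=C(c1cccnc1)N1N=C(c2ccc(O)cc2)CC1c1ccc(F)cc1` gives 52400 nM in this assay. Compound 2 `COc1ccc(C2CC(c3ccc(O)cc3)=NN2C(=O)c2cccnc2)cc1OC` gives 53600 nM in this assay, and compound 3 `O=C(c1cccnc1)N1N=C(c2ccc(O)cc2)CC1c1ccc(OCc2ccccc2)cc1` gives 11400 nM in this assay. Among these three numbers compound 2 stands highest, but its gap to compound 1 lies inside the scatter, so the two cannot be told apart; only compound 3 sits lower by more than the scatter. The step of a 1.0-fold higher number from compound 1 to compound 2 (0.01 log units; within the scatter) came with 3,4-dimethoxyphenyl in place of 4-fluorophenyl on a saturated ring carbon. The step of a 4.6-fold lower number from compound 1 to compound 3 (0.66 log units; beyond the scatter) came with benzyloxy in place of fluoro on an aromatic carbon.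

Compound 4 `COc1ccc(OC)c(C2CC(c3ccc(O)cc3)=NN2C(=O)c2cccnc2)c1` has not yet been measured. It differs from compound 2 in one place: 2,5-dimethoxyphenyl in place of 3,4-dimethoxyphenyl on a saturated ring carbon. The closest guide is the step from compound 1 to compound 2, where a different aryl group on that same saturated ring carbon brought no change beyond the scatter; the other step concerns another position and another kind of group, so it bears less here. Nothing measured speaks to a rearrangement of the two methoxy groups on the phenyl ring. For compound 4 a step of a 1.1-fold lower number from compound 2 to compound 4 (0.03 log units; within the scatter) is therefore expected, meaning no change beyond the scatter. Compound 4 is estimated at 50000 nM, with a range from 20000 nM to 120000 nM.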

Compound 4, half-maximal inhibitory concentration: 56800 nM
Compound 4: the middle estimate sits 1.1-fold (0.06 log units) below what was measured, and the stated range covers the measured number.
By their numbers in this assay, from the lowest: compound 3; then compounds 1, 2 and 4 (each within the scatter of the next).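

Moving the two methoxy groups around the phenyl ring on the saturated ring carbon, with the same atoms joined differently, gives a 1.1-fold higher number from compound 2 to compound 4 (0.03 log units; within the scatter) in this assay and so does not register in this measurement. Measured against the 4-fluorophenyl group, 2,5-dimethoxyphenyl gives a 1.1-fold higher number from compound 1 to compound 4 (0.04 log units; within the scatter), so compounds 1, 2 and 4 cannot be told apart, and the position has now taken three different aryl groups without a change beyond the scatter; compound 3 goes against any broader reading of flatness, since a change on that same aryl group, benzyloxy in place of fluoro, gives a 4.6-fold lower number from compound 1 to compound 3 (0.66 log units; beyond the scatter). No independent measurement is available to explain why these replacements leave the number unchanged.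

Still open, as far as these compounds go, is whether an amine or a carboxylic acid on this phenyl ring would shift the number beyond the scatter, as benzyloxy did. A longer chain, such as butoxy in place of benzyloxy, would also help to show how much of that shift depends on the chain and how much on its terminal phenyl ring.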